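A few compounds are considered here, and "the series" means these few. Any claim that something is new, unique, unknown or untested is made for them only; others in the source may bear on it.

In a functional assay on CAPAN-1 cells (Homo sapiens) for antiproliferative activity, with a stated time of 72 h (a lower number here means a stronger inhibitor, a higher number a weaker inhibitor), the measured compounds are:
Compound 1 `CCCC#Cc1cc([C@@H]2O[C@H](CO)[C@@H](O)[C@H]2O)n2ncnc(N)c12` gives 20 nM
Compound 2 `Nc1ncnn2c([C@@H]3O[C@H](CO)[C@@H](O)[C@H]3O)cc(C#Cc3ccc(F)cc3)c12` gives 55400 nM
Compound 3 `Nc1ncnn2c([C@@H]3O[C@H](CO)[C@@H](O)[C@H]3O)cc(C#Cc3cccs3)c12` gives 32000 nM

Compound 3 stands at the high end of these numbers with compound 2, the step being a 1.7-fold lower number from compound 2 to compound 3 (0.24 log units; within the scatter). Compound 4 `Nc1ncnn2c([C@@H]3O[C@H](CO)[C@@H](O)[C@H]3O)cc(-c3ccc(F)cc3F)c12` differs from compound 3 by 2,4-difluorophenyl in place of 2-(thiophen-2-yl)ethynyl on an aromatic carbon. Going by the values given here, no measured step makes this exchange. The nearest evidence is a 2800-fold higher number from compound 1 to compound 2 (3.44 log units; beyond the scatter) and a 1600-fold higher number from compound 1 to compound 3 (3.20 log units; beyond the scatter), both large, where an aromatic ring replaces propyl on the triple-bonded carbon. Compound 4 also carries an aromatic ring, so no step beyond the scatter is expected, with weak inhibition persisting. The expected change is a 1.6-fold lower number from compound 3 to compound 4 (0.20 log units; within the scatter) and remains uncertain. The estimated value for compound 4 is 20000 nM, within an expected range of 3000 nM to 70000 nM.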

Compound 4, half-maximal inhibitory concentration: 50900 nM
For compound 4 the middle estimate is 2.5-fold (0.41 log units) below the measured one, within the range that was stated.
By their numbers in this assay, from the lowest: compound 1; then compounds 3, 4 and 2 (each within the scatter of the next).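

In this assay, 2,4-difluorophenyl set directly on the aromatic carbon, with no triple bond, reads like the aromatic rings carried on one: the result is a 1.6-fold higher number from compound 3 to compound 4 (0.20 log units; within the scatter) and a 1.1-fold lower number from compound 2 to compound 4 (0.04 log units; within the scatter), both within the scatter. The contrast with the alkyl alkyne remains large, at a 2500-fold higher number from compound 1 to compound 4 (3.41 log units; beyond the scatter), so at this position the triple bond does not separate these three aromatic compounds, and only compound 1 stands apart. No evidence at hand explains this result. The compounds shown leave open whether the low number of compound 1 depends on the triple bond or on the propyl chain it carries. As far as these compounds go, a longer alkyl chain on the triple bond, or an amine at this position, remains untested here.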